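This account rests on a few compounds, and the source may have more. Where it says the series, first, only, none or still open, it means among the compounds named here.

Within the data shown here, compound 1 `Cc1cc(/C=C/C#N)cc(C)c1Oc1nc(Nc2ccc(N3CCCC(N)C3)cc2)nc2sccc12` is the one measured compound here that yields a number in an ADME assay on MT4 cells (Homo sapiens) for cytotoxicity, read by MTT assay, with a stated time of 5 days; a lower number here means that less compound is tolerated, a higher number that more compound is tolerated; in this assay compound 1 gives 4610 nM. Compound 2 `Cc1cc(/C=C/C#N)cc(C)c1Oc1nc(Nc2ccc(CN3CCN(S(N)(=O)=O)CC3)cc2)nc2sccc12` differs from it only in the group on the aromatic carbon, and in this assay compound 2 reaches only a limit, > 217000 nM. Among the measured compounds shown here, the one measured step, an at least 47-fold higher number from compound 1 to compound 2 (1.67 log units; beyond the scatter), is therefore known only as a lower bound, because the limit of > 217000 nM in this assay, at which 1 of the 2 values shown sits, caps what this assay can report. Compound 2 thus stands at the tolerated end of the two values shown, while compound 1 sits well inside the measurable range.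

Compound 3 `Cc1cc(/C=C/C#N)cc(C)c1Oc1nc(Nc2ccc(N3CCNCC3)cc2)nc2sccc12` is not yet measured in this assay. It arises from compound 2 by the change (piperazin-1-yl in place of (4-sulfamoylpiperazin-1-yl)methyl on an aromatic carbon). For the measured compounds named here, the only step that bears on it is an at least 47-fold higher number from compound 1 to compound 2 (1.67 log units; beyond the scatter), which moved in the opposite direction when an amine-bearing ring was swapped for the sulfamoyl-bearing group; its size is known only as a bound. Compound 3 is therefore expected to shift as an at least 18-fold lower number from compound 2 to compound 3 (1.25 log units; beyond the scatter), back toward the range of compound 1. The estimate for compound 3 in this assay is 12000 nM, with a plausible range from 3000 nM to 100000 nM.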

Compound 3, half-maximal cytotoxic concentration: 4740 nM
Compound 3: the middle estimate sits 2.5-fold (0.40 log units) above what was measured; low and high end bracket the measured number.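

The change on this aromatic carbon, piperazin-1-yl in place of (4-sulfamoylpiperazin-1-yl)methyl, gives an at least 45-fold lower number from compound 2 to compound 3 (1.66 log units; beyond the scatter) in this assay, so a piperazine ring at this position does not by itself carry the high number. Piperazin-1-yl in place of 3-aminopiperidin-1-yl gives a 1.0-fold higher number from compound 1 to compound 3 (0.01 log units; within the scatter), which shows that these two rings cannot be told apart here, while compound 2, with its sulfamoyl-bearing group, is the one compound that goes against this shared level. The larger step remains a bound, and its full size cannot be read: the limit of > 217000 nM in this assay, at which 1 of the 3 values shown sits.

The change from compound 2 to compound 3 removes the sulfamoyl group and the methylene link together, so the compounds shown cannot assign the step to either one; piperazin-1-ylmethyl or 4-sulfamoylpiperazin-1-yl on the same carbon would separate the two. On these data alone, it also remains open whether another group on the piperazine nitrogen, such as an acetyl or a methanesulfonyl, would move the number as the sulfamoyl-bearing group does.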